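Aminopyrazinyl variant of a fused pentacyclic series

This account rests on a few compounds, and the source may have more. Where it says the series, first, only, none or still open, it means among the compounds named here.

Measured so far:
compound 1 `Cc1nc2c3ccccc3ccc2c2nc3c(ccc4ccccc43)c(-c3ccccc3Cl)c12`: 118 ug/mL
compound 2 `Cc1ccc(-c2c3ccc4ccccc4c3nc3c2c(C)nc2c4ccccc4ccc32)cc1`: 123 ug/mL
compound 3 `Cc1nc2c3ccccc3ccc2c2nc3c(ccc4ccccc43)c(-c3ccccc3)c12`: 164 ug/mL

Notes. Compound 3 carries a plain phenyl on the shared core, whereas compound 1 carries 2-chlorophenyl and compound 2 carries 4-methylphenyl. In a functional assay, read by spectrophotometry, with a stated time of 30 min (a higher number here means a weaker inhibitor, a lower number a stronger inhibitor), compound 3 gives 164 ug/mL, the highest of the three numbers, but the gap to its neighbours is small: a 1.3-fold higher number from compound 2 to compound 3 (0.12 log units; within the scatter) and a 1.4-fold higher number from compound 1 to compound 3 (0.14 log units; within the scatter), so nothing separates the three compounds beyond the usual scatter.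

Compound 4 `Cc1nc2c3ccccc3ccc2c2nc3c(ccc4ccccc43)c(-c3nccnc3N)c12` has not yet been measured. Relative to compound 3 the change is 3-aminopyrazin-2-yl in place of phenyl on an aromatic carbon. The two steps that touch the same aromatic carbon, a 1.4-fold higher number from compound 1 to compound 3 (0.14 log units; within the scatter) and a 1.3-fold higher number from compound 2 to compound 3 (0.12 log units; within the scatter), show that exchanging one substituent on that ring for another made no difference beyond the scatter. Neither step, however, puts a heteroaryl ring bearing a donor at this position, so the present change reaches outside what the measured compounds cover. Among the compounds with values here, with no step pointing in either direction, no movement beyond the scatter is expected, and the uncertainty is set wider than for a plain repeat.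

For compound 4 in this assay the estimate is 150 ug/mL, with a range of 70 ug/mL to 320 ug/mL, which corresponds to an expected step of a 1.1-fold lower number from compound 3 to compound 4 (0.04 log units; within the scatter).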

Compound 4, half-maximal inhibitory concentration: 81.7 ug/mL
For compound 4 the middle estimate is 1.8-fold (0.26 log units) above the measured one; measured number inside the range.
By their numbers in this assay, from the lowest: compounds 4, 1, 2 and 3 (each within the scatter of the next).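

In this assay, the substituent on this aromatic carbon now extends from rings of carbon only to 3-aminopyrazin-2-yl, a six-membered aromatic ring with 2 hetero atoms that also carries a hydrogen-bond donor, and all three new steps stay within the scatter: a 2.0-fold lower number from compound 3 to compound 4 (0.30 log units; within the scatter), a 1.5-fold lower number from compound 2 to compound 4 (0.18 log units; within the scatter) and a 1.4-fold lower number from compound 1 to compound 4 (0.16 log units; within the scatter). The earlier steps shown here covered only exchanges among phenyl, 2-chlorophenyl and 4-methylphenyl, so across these four compounds the position shows no need for a ring of carbon only and no measurable gain from the heteroaryl ring with its amino group. No available evidence bears on this result.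

The compounds shown leave open whether the ring nitrogens and the amino group count separately, which plain pyrazin-2-yl and 2-aminophenyl at the same carbon would test. They also leave open whether any group at this carbon moves the number beyond the scatter, for instance a carboxylic acid, a morpholine or a longer alkyl chain in place of the aromatic ring.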